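This account rests on a few compounds, and the source may have more. Where it says the series, first, only, none or still open, it means among the compounds named here.

Working notes on the series.

Of the compounds shown here, two carry numbers so far. In a functional assay on the whole organism (strain CF-1) with Mus musculus as the target (a lower number here means that less compound is needed, a higher number that more compound is needed for the effect), compound 1 `Cc1nnc(CN2CCCC2)n1-c1ccc(Cl)cc1Cc1ccccc1` gives 40 mg/kg, the highest of the two numbers at hand. Its nearest neighbour, compound 2 `CN(C)Cc1nccn1-c1ccc(Cl)cc1C(=O)c1ccccc1Cl`, gives 2.2 mg/kg in this assay, a gap that is beyond the scatter. Compound 2 differs from compound 1 in more than one place, so nothing is known about what any single part of that difference contributes.

Compound 3 `Cc1nnc(CN2CCCC2)n1-c1ccc(Cl)cc1C(=O)c1ccccc1Cl` is the next to be measured and differs from compound 1 in one place: (2-chlorophenyl)carbonyl in place of benzyl on an aromatic carbon. The entering group is the same one that compound 2 carries on the same aromatic carbon, while compound 3 keeps the core of compound 1.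

Going by the values given here, no single-change step between measured compounds exists here, so the size of the step is an open question. Given that compound 2 shows 2.2 mg/kg with the entering group in place, the step from compound 1 to compound 3 is expected to be downward, roughly a 5.0-fold lower number from compound 1 to compound 3 (0.70 log units; beyond the scatter). For compound 3 in this assay a value around 8 mg/kg is estimated, between 2.5 mg/kg and 25 mg/kg.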

Compound 3, dose for half-maximal effect: 1 mg/kg
Estimate against measurement, compound 3: 8.0-fold (0.90 log units) above; the measured number lies below the stated range.
By their numbers in this assay, from the lowest: compound 3; then compound 2; then compound 1.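

Working notes, continued.

In this assay, going by these compounds alone, (2-chlorophenyl)carbonyl in place of benzyl, on the aromatic carbon that is ortho to a large group and meta to a chloro group, gives a 40-fold lower number from compound 1 to compound 3 (1.60 log units; beyond the scatter), a large step and the first reading of a single change. With the core of compound 1 kept, this position alone is now shown to move the number well beyond the scatter, which the earlier pair of compounds, differing in more than one place, could not show. The change brings in a carbonyl, with one hydrogen-bond acceptor, and a chlorine on the entering ring all at once, and no measurement at hand explains the size of the step.

What the compounds shown leave open is how the step divides between these parts: a plain benzoyl group and a 2-chlorobenzyl group on the same carbon would separate the carbonyl from the chlorine. Also open, on these data alone, is how the number responds to a fluoro or methyl group in place of the chlorine on the entering ring.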